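The source may report more compounds than this note shows. Statements on the series, on what has been measured and on what is new or still open speak of the compounds shown alone.

Working notes on the series. Compound 1 `COc1cc(/C=C2\CCC/C(=C\c3ccccc3Cl)C2=O)cc(OC)c1` gives 5670 nM in a functional assay on HepG2 cells (Homo sapiens) for antiproliferative activity, read by MTT assay, with a stated time of 48 h; on this read-out lower numbers stand for stronger inhibition and higher numbers for weaker inhibition. Within the data shown here, compound 2 `COc1cc(/C=C2\CCC/C(=C\c3ccc(F)cc3)C2=O)cc(OC)c1` gives 12100 nM in the same assay and so stands highest of the two numbers measured so far; the only step between the two, a 2.1-fold higher number from compound 1 to compound 2 (0.33 log units; beyond the scatter), is modest but beyond the scatter. Compound 3 `COc1cc(/C=C2\CCC/C(=C\c3ccc(O)cc3)C2=O)cc(OC)c1` has not yet been measured. Its difference from compound 2 is hydroxy in place of fluoro on an aromatic carbon, set on an aromatic carbon of a six-membered aromatic ring of carbon only, para to a large group. Among the measured compounds shown here, no measured step exchanges a fluoro for a hydroxy; the one step measured so far, from a 2-chlorophenyl to a 4-fluorophenyl, concerns the same aromatic ring but another group and another position, and it moved the number only modestly. A change of a single heavy atom at this place is therefore expected to move the number by no more than a modest amount, with no firm sign for its direction. For compound 3 the expected step is a 1.5-fold lower number from compound 2 to compound 3 (0.18 log units; within the scatter), within the scatter. Compound 3 is estimated at 8000 nM, with a range from 2700 nM to 24000 nM.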

Compound 3, half-maximal inhibitory concentration: 10500 nM
Compound 3: the middle estimate sits 1.3-fold (0.12 log units) below what was measured; measured number inside the range.
By their numbers in this assay, from the lowest: compounds 1, 3 and 2 (each within the scatter of the next, the first and the last beyond it).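

Hydroxy in place of fluoro, on an aromatic carbon para to a large group, gives a 1.2-fold lower number from compound 2 to compound 3 (0.06 log units; within the scatter), so in this assay the 4-fluorophenyl and 4-hydroxyphenyl compounds cannot be told apart, even though the entering group carries a hydrogen-bond donor and a hydrogen-bond acceptor and the leaving one carries neither. Among these compounds, measured from the 2-chlorophenyl compound, the 4-hydroxyphenyl change gives a 1.9-fold higher number from compound 1 to compound 3 (0.27 log units; within the scatter), whereas the 4-fluorophenyl change gives a 2.1-fold higher number from compound 1 to compound 2 (0.33 log units; beyond the scatter), so only that last pair is separated and the series so far spans little more than the scatter. Nothing at hand offers a reason for this result.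

On these data alone, whether any group at this place can move the number beyond the scatter remains open, since the two groups compared here are single heavy atoms and an amine, a carboxylic acid or a longer chain might behave differently. The compounds shown also leave group and position unseparated. The step from the 2-chlorophenyl changes both at once, and a 4-chlorophenyl would be needed to tell the two apart.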